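A Bromine Joins the Phenyl Ring of Compound 3

The source may report more compounds than this note shows. Statements on the series, on what has been measured and on what is new or still open speak of the compounds shown alone.

Three measured compounds share one core and a chain that ends in a phenyl ring. In a functional assay on SW480 cells (Homo sapiens) for antiproliferative activity, read by MTT assay, with a stated time of 48 h (on this read-out higher numbers stand for weaker inhibition and lower numbers for stronger inhibition), compound 1 `Nc1nc(N2CCCC2)sc1C(=O)/C=C/c1ccccc1` gives 31.7 ug/mL. Compound 2 `Nc1nc(N2CCCC2)sc1C(=O)/C=C/c1ccc(Cl)cc1Cl`, which carries chlorine substituents on its phenyl ring, gives 18.4 ug/mL in this assay. Compound 3 `Nc1nc(N2CCCCC2)sc1C(=O)/C=C/c1ccccc1` gives 28.1 ug/mL in this assay, the second highest of the three numbers; its nearest neighbour is compound 1, and the step of a 1.1-fold lower number from compound 1 to compound 3 (0.05 log units; within the scatter) lies within the scatter of the measurement.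

Compound 4 `Nc1nc(N2CCCCC2)sc1C(=O)/C=C/c1ccc(Br)cc1` differs from compound 3 by bromo in place of hydrogen on an aromatic carbon. For the measured compounds named here, no measured step adds a single halogen to the phenyl ring, so the only guide is the pair of compound 1 and compound 2, whose numbers lie close together and show at most a modest shift toward a lower number when the phenyl ring carries chlorine. The step of a 1.3-fold lower number from compound 3 to compound 4 (0.11 log units; within the scatter) is therefore expected to be small, toward a somewhat lower number if anything. Compound 4 is estimated at 22 ug/mL, with a range from 11 ug/mL to 44 ug/mL.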

Compound 4, half-maximal inhibitory concentration: 31.6 ug/mL
The estimate for compound 4 lay 1.4-fold (0.16 log units) below the measured number; low and high end bracket the measured number.
By their numbers in this assay, from the lowest: compounds 2, 3, 4 and 1 (each within the scatter of the next).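

In this assay the change reads as a 1.1-fold higher number from compound 3 to compound 4 (0.05 log units; within the scatter) and so a bromo group on the phenyl ring, para to a large group, gives a number that cannot be told apart from that of the plain phenyl compound. This is the first step shown that adds one halogen atom to this ring, and with piperidin-1-yl on the core that single heavy atom does not move the number beyond the scatter. No measurement at hand offers an explanation for this result.

Going by these compounds, it remains open whether a different group at this place on the ring, such as an amine, a carboxylic acid or a longer chain, would give a number beyond the scatter. Also open, on these data alone, is whether bromo would read the same with pyrrolidin-1-yl on the core.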